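A Longer Chain on the Shared Core: Compound 4

A few compounds are considered here, and "the series" means these few. Any claim that something is new, unique, unknown or untested is made for them only; others in the source may bear on it.

Compound 1 `CC(C)=CCC1Cc2c(OCCCNC(=O)c3ccco3)cc(=O)n(CCCO)c2CC1(C)C` — 4.3%
Compound 2 `CC(C)=CCC1Cc2c(OC(=O)Nc3ccc(F)cc3F)cc(=O)n(CCCO)c2CC1(C)C` — 0%
Compound 3 `CC(C)=CCC1Cc2c(OC(=O)Nc3ccc(Cl)c(Cl)c3)cc(=O)n(CCCO)c2CC1(C)C` — 1.8%

All three compounds were tested in a functional assay on PANC-1 cells (Homo sapiens) for inhibition, read by MTT assay, with a stated time of 24 h, tested at 10 uM; on this read-out lower numbers stand for less inhibition and higher numbers for more inhibition at the one concentration tested (going by the name of the read-out). Compound 1 sits within the scatter of both other compounds: the step of a number 2.5 percentage points lower from compound 1 to compound 3 (within the scatter) and the step of a number 4.3 percentage points lower from compound 1 to compound 2 (within the scatter) are both small, and the step of a number 1.8 percentage points higher from compound 2 to compound 3 (within the scatter) is small as well. On these numbers the three compounds cannot be told apart in this assay.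

Compound 4 `CC(C)=CCC/C(C)=C/CC1Cc2c(OCCCNC(=O)c3ccco3)cc(=O)n(CCCO)c2CC1(C)C` differs from compound 1 in one place: 3-methylbut-2-en-1-yl in place of hydrogen on a saturated chain carbon bound to a double-bonded chain carbon. The change lies on the side chain of the shared core, not on the oxygen-borne substituent that was varied between compound 1, compound 2 and compound 3. Among the measured compounds shown here, none of the measured steps therefore bears on this change, and all of them were within the scatter anyway.

For the measured compounds named here, with no step pointing in either direction, compound 4 is expected to behave like compound 1, and the step of a number 0.7 percentage points higher from compound 1 to compound 4 (within the scatter) is estimated to stay within the scatter. The estimate for compound 4 in this assay is 5%, with a range from 0% to 15%.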

Compound 4, a percentage reported as inhibition, at one concentration (the size of the read-out at that concentration, not a potency): 2.8%
Beside the measured number, compound 4's estimate is 2.2 percentage points above it; measured number inside the range.
By their numbers in this assay, from the lowest: compounds 2, 3, 4 and 1 (each within the scatter of the next).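

The earlier compounds shown here differed only in the substituent on the oxygen, whereas this comparison concerns the side chain of the shared core. Going from 3-methylbut-2-en-1-yl to 3,7-dimethylocta-2,6-dien-1-yl at this place gives, in this assay, a number 1.5 percentage points lower from compound 1 to compound 4 (within the scatter), so the longer chain, placed on a saturated chain carbon bound to a double-bonded chain carbon, yields a number that cannot be told apart from that of the shorter chain. No data shown offer an explanation for this result.

Because both chains carry the furan-2-yl amide on the oxygen, the compounds shown leave open whether the longer chain would read the same alongside a (3,4-dichlorophenyl)carbamoyl or (2,4-difluorophenyl)carbamoyl group on that oxygen. They also leave open whether a chain ending in an amine or a carboxylic acid, or a fully saturated chain in place of 3,7-dimethylocta-2,6-dien-1-yl, would give a number beyond the scatter of those seen so far.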